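Swapping an aromatic amide for a protected pyrrolidine

This account rests on a few compounds, and the source may have more. Where it says the series, first, only, none or still open, it means among the compounds named here.

Measured so far:
Compound 1 `O=C(c1ccc(Cl)cc1)N1CCC(NS(=O)(=O)c2cc(S(=O)(=O)c3ccccc3)ccc2C(F)(F)F)CC1` gives 3100 nM in a physicochemical assay for solubility; a lower number here means a less soluble compound, a higher number a more soluble compound.
Compound 2 `CC(C)(C)OC(=O)N1CCC(CC(=O)N2CCC(NS(=O)(=O)c3cc(S(=O)(=O)c4ccccc4)ccc3C(F)(F)F)CC2)CC1` gives 12500 nM in this assay.

Compound 1 holds the lower of the two numbers; compound 2 sits higher by a gap beyond the usual scatter. Compound 3 `CC(C)(C)OC(=O)N1CCC[C@@H]1C(=O)N1CCC(NS(=O)(=O)c2cc(S(=O)(=O)c3ccccc3)ccc2C(F)(F)F)CC1` is not yet measured. It differs from compound 1 in one place: 1-(tert-butoxycarbonyl)pyrrolidin-2-yl in place of 4-chlorophenyl on a carbonyl carbon. For the measured compounds named here, no measured pair shows this exact change, so the only guide is compound 2, whose result in this assay of 12500 nM points toward a higher number. The expected step is a 2.6-fold higher number from compound 1 to compound 3 (0.41 log units; beyond the scatter), a modest rise. Compound 3 is estimated at 8000 nM, within 3000 nM to 20000 nM.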

Compound 3, solubility: 25000 nM
The estimate for compound 3 lay 3.1-fold (0.49 log units) below the measured number, outside the stated range (above it).
By their numbers in this assay, from the lowest: compound 1; then compounds 2 and 3 (each within the scatter of the next).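

For the compounds shown here, with the core of compound 1 left unchanged, placing 1-(tert-butoxycarbonyl)pyrrolidin-2-yl instead of 4-chlorophenyl on the carbonyl carbon gives an 8.1-fold higher number from compound 1 to compound 3 (0.91 log units; beyond the scatter) in this assay and is the first single-place change read at this position. It shows that the group on this carbonyl carbon can move the number well beyond the scatter. No measurement shown here gives a reason for the rise.

As far as these compounds go, it remains open whether the rise follows the pyrrolidine ring or its tert-butoxycarbonyl group. A free pyrrolidine amine or a plain cyclohexyl ring at this place would help separate the two.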